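Notes on the step from compound 3 to compound 4

The compounds below may be only part of what the source reports. "The series", "measured", "known", "first", "only" and "open" are said of these compounds alone.

Measured so far in a functional assay on cells (Ovarian carcinoma cell, Homo sapiens) for cytotoxicity, read by sulforhodamine B assay, with a stated time of 48 h; on this read-out lower numbers stand for higher toxicity in this test and higher numbers for lower toxicity in this test:
- compound 1 `COc1cc2c(cc1C)NC(=O)/C2=C/c1c(OC)nc2sc(C)cn12` gives 91400 nM
- compound 2 `O=C1Nc2ccccc2C1=Cc1c(-c2ccncc2)nc2sccn12` gives 91800 nM
- compound 3 `COc1ccc2c(c1)/C(=C\c1c(OC)nc3sc(C)cn13)C(=O)N2` gives 87600 nM

Compound 3 stands within the scatter of both compound 1 and compound 2, so the three numbers cannot be ranked. Compound 4 `COc1nc2sc(C)cn2c1/C=C1/C(=O)Nc2ccccc21` differs from compound 3 as follows: hydrogen in place of methoxy on an aromatic carbon and this amounts to hydrogen in place of methoxy on an aromatic carbon. Among the compounds with values here, no measured step covers this exact change, and compound 2 offers no step that differs in one place only. The nearest evidence is hydrogen in place of methyl on an aromatic carbon, which gave a 1.0-fold lower number from compound 1 to compound 3 (0.02 log units; within the scatter) and so stayed small. That single step is thin support for a different leaving group. Even so, no change beyond the scatter is expected in this assay and no direction can be favoured. The estimate amounts to a 1.0-fold higher number from compound 3 to compound 4 (0.01 log units; within the scatter) and is therefore an expected step of no real size. For compound 4 the expected value is 90000 nM with an estimated range from 55000 nM to 125000 nM as the working figure.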

Compound 4, concentration lethal to 50% of the cells: 96300 nM
Compound 4: middle estimate off by 1.1-fold (0.03 log units), on the low side; the measured number falls inside the stated range.
By their numbers in this assay, from the lowest: compounds 3, 1, 2 and 4 (each within the scatter of the next).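

In this assay, hydrogen in place of methoxy on an aromatic carbon of the six-membered aromatic ring of carbon only, meta to a fused ring and para to a fused ring, gives no readable change (a 1.1-fold higher number from compound 3 to compound 4 (0.04 log units; within the scatter)). Alongside the earlier single change on this ring (a 1.0-fold lower number from compound 1 to compound 3 (0.02 log units; within the scatter)), this is a second step within the scatter, and the first to remove the methoxy at this place. Nothing measured on the compounds explains this flat result.

On these data alone, whether an amine, a carboxylic acid or a longer chain at this place would give a step beyond the scatter remains open. Also open, as far as these compounds go, is whether the methoxy elsewhere on the core, kept in both compound 3 and compound 4, can be replaced without a readable change.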